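Shortening a Side Chain While Keeping the Shared Core

A few compounds are considered here, and "the series" means these few. Any claim that something is new, unique, unknown or untested is made for them only; others in the source may bear on it.

Of the compounds shown here, two have been tested so far in a functional assay on the whole organism (Abdomen, strain Swiss) for inhibition, with Mus musculus as the target, with stated times of 30 min, 10 min and 5 min, at a dose of 10 mg/kg by the oral route; on this read-out higher numbers stand for a stronger effect at the one dose given and lower numbers for a weaker effect. Compound 1, `CCC(=O)c1c(C)nn(CCCN2CCN(c3ccc(C)cc3)CC2)c(=O)c1N`, gives 9%. Compound 2, `CC/C=C/c1c(C)nn(CCCN2CCN(c3ccc(C)cc3)CC2)c(=O)c1N`, gives 5%. Compound 2 stands at the lowest of the two numbers, but the step of a number 4 percentage points lower from compound 1 to compound 2 (within the scatter) is within the scatter, so the two compounds cannot be told apart on this read-out.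

Compound 3, `CCc1c(C)nn(CCCN2CCN(c3ccc(C)cc3)CC2)c(=O)c1N`, differs from compound 2 by ethyl in place of but-1-en-1-yl on an aromatic carbon. Going by the values given here, the only measured step, but-1-en-1-yl in place of propanoyl on an aromatic carbon, concerns a different exchange of group and was itself small, so no measured step speaks directly to swapping but-1-en-1-yl for ethyl. Among the compounds with values here, both measured compounds sit low, and the one change already examined at this aromatic carbon left the number essentially unmoved. On that basis compound 3 is expected to sit low as well, with an estimated step of a number 2 percentage points higher from compound 2 to compound 3 (within the scatter) that stays within the scatter. The estimate for compound 3 is 7%, with a range from 0% to 20%.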

Compound 3, a percentage reported as inhibition, in the whole organism at one dose (the size of the read-out at that dose, not a potency): 23%
Compound 3: the middle estimate sits 16 percentage points below what was measured; measured number outside the range, above it.
By their numbers in this assay, from the lowest: compounds 2 and 1 (each within the scatter of the next); then compound 3.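

Measured by this assay this aromatic carbon now proves sensitive to the group it carries: ethyl gives a number 18 percentage points higher from compound 2 to compound 3 (beyond the scatter) when it replaces but-1-en-1-yl and a number 14 percentage points higher from compound 1 to compound 3 (beyond the scatter) when it replaces propanoyl. The earlier pair could not be told apart, which made the position look indifferent, whereas compound 3 now stands clear of both compound 1 and compound 2, though only modestly and at a single dose, so this is the size of an effect and not a potency. Nothing available here explains why ethyl behaves differently from the other two groups.

The three compounds do not separate chain length from the double bond or the carbonyl, since ethyl, with 2 heavy atoms, differs from but-1-en-1-yl, with 4 heavy atoms, in both size and the double bond, and a saturated butyl or propyl chain at this carbon would be needed to pull those apart. Also open, going by these compounds, is how a group of another kind at this carbon, such as an amine or a carboxylic acid, would compare with ethyl, and whether the gap would hold at other doses.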